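The compounds below may be only part of what the source reports. "The series", "measured", "known", "first", "only" and "open" are said of these compounds alone.

Measured so far:

Compound 1, `Cc1nc2c(OCc3ccccc3)cccn2c1CCC#N`: 20% in a functional assay on the whole organism (stomach) for inhibition, with Canis familiaris (Canis lupus familiaris) as the target, at a dose of 5 mg/kg by the intravenous route; on this read-out higher numbers stand for a stronger effect at the one dose given and lower numbers for a weaker effect
Compound 2, `COC(=O)Cc1c(C)nc2c(OCc3ccccc3)cccn12`: 16% in this assay

Of the two numbers shown, compound 2 gives the lower one, yet the step of a number 4 percentage points lower from compound 1 to compound 2 (within the scatter) lies within the scatter of repeated measurements, so the two compounds cannot really be told apart on this read-out.

The compound not yet measured is compound 3, `Cc1nc2c(OCc3ccccc3)cccn2c1COC(=O)N(C)C`. It differs from compound 2 in one place: (dimethylcarbamoyl)oxy in place of methoxycarbonyl on a saturated chain carbon bound to an aromatic carbon. Among the compounds with values here, only one measured step bears on this change, the step from compound 1 to compound 2, which also exchanged the group on that same saturated chain carbon and came out as a number 4 percentage points lower from compound 1 to compound 2 (within the scatter). That single step was small, and there is no further information on how this position answers to a change of group. The expected step of no change at the digits printed from compound 2 to compound 3 (within the scatter) is therefore estimated to stay within the scatter, in no particular direction. On this basis compound 3 is expected to give 16% in this assay, with a range estimated from 4% to 32%.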

Compound 3, a percentage reported as inhibition, in the whole organism at one dose (the size of the read-out at that dose, not a potency): 23%
For compound 3 the middle estimate is 7 percentage points below the measured one; measured number inside the range.
By their numbers in this assay, from the lowest: compounds 2, 1 and 3 (each within the scatter of the next).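

With a third group now on the saturated chain carbon bound to an aromatic carbon, this assay gives two new steps to read: a number 7 percentage points higher from compound 2 to compound 3 (within the scatter) for (dimethylcarbamoyl)oxy in place of methoxycarbonyl, and a number 3 percentage points higher from compound 1 to compound 3 (within the scatter) for (dimethylcarbamoyl)oxy in place of cyanomethyl. The earlier compounds shown here offered a single small step at this position, whereas three groups can now be compared, and no two of them can be told apart on this read-out, even though (dimethylcarbamoyl)oxy has 6 heavy atoms against 4 in methoxycarbonyl and brings in a nitrogen. No measurement at hand offers an explanation for this flat picture.

From the compounds shown here alone, it remains open whether any group on this carbon can move the number beyond the scatter, for instance an amine, a carboxylic acid or a longer chain of plain carbons. The read-out also gives only the size of the effect at one dose, so any difference in potency among these three compounds stays unknown.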